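This account rests on a few compounds, and the source may have more. Where it says the series, first, only, none or still open, it means among the compounds named here.

Measured so far:
- compound 1 `CCN1CCN(c2nc(C)nc3c2nc(-c2ccccc2Cl)n3C)CC1`; in an ADME assay (liver) for metabolic stability, with Liver microsome (Homo sapiens) as the target, read by LC-MS, using microsomes, with a stated time of 30 min, tested at 4 uM (on this read-out lower numbers stand for a less stable compound and higher numbers for a more stable compound), compound 1 gives 7%
- compound 2 `Cc1nc(N2CCN(C)CC2)c2nc(-c3cccc(C(F)(F)F)c3)n(C3CCOCC3)c2n1`; in this assay compound 2 gives 19%

Compound 2 stands highest of the two numbers; its nearest neighbour is compound 1, which sits lower by a gap beyond the usual scatter. Compound 3 `CCc1ccccc1-c1nc2c(N3CCN(C)CC3)nc(C)nc2n1C1CCOCC1` is not yet measured. It differs from compound 2 in one place: 2-ethylphenyl in place of 3-(trifluoromethyl)phenyl on an aromatic carbon. For the measured compounds named here, no measured pair covers this change, so no step of this kind is known in this assay; a small step in either direction, or none beyond the scatter, is possible. Compound 3 is expected to give 15% in this assay, within 5% to 32%. The step this estimate implies is a number 4 percentage points lower from compound 2 to compound 3 (within the scatter), expected to lie within the scatter.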

Compound 3, percent of the compound remaining: 33%
The estimate for compound 3 lay 18 percentage points below the measured number, and the stated range ends below it.
By their numbers in this assay, from the lowest: compound 1; then compound 2; then compound 3.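

At this aromatic carbon, next to the ring atom that bears the oxan-4-yl group, the aryl group can shift this assay: 2-ethylphenyl in place of 3-(trifluoromethyl)phenyl gives a number 14 percentage points higher from compound 2 to compound 3 (beyond the scatter). For the compounds shown here, this is the first single-place step, and it shows that this position is not silent. Nothing measured here accounts for the step.

A single pair cannot separate the ethyl group from its place on the phenyl ring, and 2-(trifluoromethyl)phenyl or 3-ethylphenyl would bear on that. Also open, going by these compounds, is how a phenyl ring carrying an amine or a carboxylic acid would read at this carbon.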